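Fluoro on the biaryl ring: one precedent, one prediction

The source may report more compounds than this note shows. Statements on the series, on what has been measured and on what is new or still open speak of the compounds shown alone.

Measured in a functional assay on Jurkat cells (Homo sapiens) for activation, with a stated time of 24 h; on this read-out higher numbers stand for an effect only at larger amounts of compound and lower numbers for an effect already at smaller amounts:
compound 1 `Oc1ccccc1CNc1ccc(-c2ccccc2)cc1`: 1820 nM
compound 2 `CCOc1ccc(-c2ccc(NCc3ccccc3O)cc2)cc1`: 520 nM
compound 3 `CCOc1ccc(-c2ccc(NCc3ccccc3O)cc2)cc1F`: 2530 nM

Compound 1 and compound 2 share a core and differ only by hydrogen in place of ethoxy on an aromatic carbon; the step is a 3.5-fold lower number from compound 1 to compound 2 (0.54 log units; beyond the scatter). Adding fluorine to compound 2, (fluoro in place of hydrogen on an aromatic carbon), gives a 4.9-fold higher number from compound 2 to compound 3 (0.69 log units; beyond the scatter), so the fluorinated compound 3 sits close to compound 1 in this assay .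

Compound 4 `Oc1ccccc1CNc1ccc(-c2ccccc2)cc1F` is the fluorinated counterpart of compound 1, the change being (fluoro in place of hydrogen on an aromatic carbon). This is the same kind of change as from compound 2 to compound 3, not the same: around the new fluorine the surroundings differ, being ortho to a group of 9 heavy atoms and meta to a phenyl group in compound 4, against ortho to an ethoxy group and meta to a large group in compound 3.

With a single precedent, the expected step is a 3.3-fold higher number from compound 1 to compound 4 (0.52 log units; beyond the scatter), resting on a 4.9-fold higher number from compound 2 to compound 3 (0.69 log units; beyond the scatter). The surroundings of the new fluorine differ between the two cases, and the range is set wide. The estimate for compound 4 in this assay is 6000 nM, expected between 2000 nM and 18000 nM.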

Compound 4, half-maximal effective concentration: 5350 nM
Estimate against measurement, compound 4: 1.1-fold (0.05 log units) above; low and high end bracket the measured number.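

On the core of compound 1, fluoro in place of hydrogen on an aromatic carbon again moves the read-out upward in this assay, with a 2.9-fold higher number from compound 1 to compound 4 (0.47 log units; beyond the scatter). Set beside the earlier case, the two steps point the same way and cannot be told apart in size: the same change on two cores in this assay, a 4.9-fold higher number (0.69 log units; beyond the scatter) from compound 2 to compound 3 and a 2.9-fold higher number (0.47 log units; beyond the scatter) from compound 1 to compound 4, 1.7-fold (0.22 log units) apart, within the scatter of two such steps

Within this pair of cores the change therefore carries over, even though the new fluorine is ortho to an ethoxy group in one case and has no such neighbour in the other; this does not establish a rule for other cores, since two steps on two cores are all that is available, and it gives no explanation for the rise.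

Left open is whether chloro or methoxy at the same place would shift the number as fluoro does. Also open, going by these compounds, is whether the step survives when the ethoxy group gives way to a longer chain such as butoxy, or to a carboxylic acid or an amine.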